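Dichlorophenyl Analogue Following an Inactive Methylphenyl Compound

The source may report more compounds than this note shows. Statements on the series, on what has been measured and on what is new or still open speak of the compounds shown alone.

The series shares one core, carried by compound 1 `C=CCn1c(=O)/c(=C\c2cccc(F)c2)[nH]c(=O)/c1=C\c1ccccc1OC`, compound 2 `C=CCn1c(=O)/c(=C\c2cccc(Cl)c2)[nH]c(=O)/c1=C\c1ccccc1OC` and compound 3 `C=CCn1c(=O)/c(=C\c2ccc(C)cc2)[nH]c(=O)/c1=C\c1ccccc1OC`. Among the compounds with values here, in a functional assay on HL-60 cells (Homo sapiens) for cytotoxicity, read by CCK-8 assay, with a stated time of 72 h (a higher number here means a weaker inhibitor, a lower number a stronger inhibitor), compound 1 gives 8890 nM, and compound 2 gives 4500 nM; the step of a 2.0-fold lower number from compound 1 to compound 2 (0.30 log units; within the scatter) is the only single-point change with numbers on both sides. Compound 3, bearing a 4-methylphenyl, is reported in this assay as "not active" (no number reported), so no number fixes where it stands relative to compound 1 and compound 2.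

Compound 4 `C=CCn1c(=O)/c(=C\c2ccc(Cl)c(Cl)c2)[nH]c(=O)/c1=C\c1ccccc1OC` differs from compound 3 in one place: 3,4-dichlorophenyl in place of 4-methylphenyl on a double-bonded chain carbon bound to an aromatic carbon. Within the data shown here, no measured step covers this change. The step of a 2.0-fold lower number from compound 1 to compound 2 (0.30 log units; within the scatter) shows that one halogen in place of another on that aromatic ring moves the number only within the usual scatter, and compound 2 shows that a chlorine-bearing phenyl is compatible with activity. Among the measured compounds shown here, since compound 3 has no number, no step from it can be sized, and the expectation for compound 4 rests on compound 2 alone. Compound 4 is therefore estimated at about 6000 nM in this assay, with a range from 1500 nM to 30000 nM.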

Compound 4, half-maximal inhibitory concentration: "not active" (no number reported)
Compound 4: no number reported; no gap can be computed for the estimate.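

Within the data shown here, compound 3 and compound 4 are both reported as "not active" in this assay and no step between them can be read. No measured evidence bears on this result. The compounds shown leave open what separates these two from compound 1 and compound 2.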